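Working notes: from compound 2 to compound 3

The source may hold more compounds than are shown below. What is called first, only, known or untested is meant among the compounds shown, and "the series" means these compounds.

In an ADME assay on Jurkat cells (Homo sapiens) for cytotoxicity, read by trypan blue exclusion, with a stated time of 24 h (a lower number here means a stronger inhibitor, a higher number a weaker inhibitor), compound 1 `N#C[Se]c1ccc(N)cc1` gives 43800 nM, while compound 2 `N#C[Se]Cc1ccc([N+](=O)[O-])cc1` gives 6860 nM, the lower of the two numbers and beyond the scatter of compound 1. Compound 3 `CSc1ccc(C[Se]C#N)cc1` carries methylsulfanyl in place of nitro on an aromatic carbon, para to a group of 4 heavy atoms: methylsulfanyl in place of nitro on an aromatic carbon. For the measured compounds named here, no measured pair isolates this change, so the expectation stays anchored on compound 2 at 6860 nM. A slight upward move, not beyond the scatter, is expected, with an estimated 1.3-fold higher number from compound 2 to compound 3 (0.12 log units; within the scatter). For compound 3 the estimated value is 9000 nM, with an expected range of 3500 nM to 23000 nM.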

Compound 3, half-maximal inhibitory concentration: 5070 nM
Compound 3: the middle estimate sits 1.8-fold (0.25 log units) above what was measured; low and high end bracket the measured number.
By their numbers in this assay, from the lowest: compounds 3 and 2 (each within the scatter of the next); then compound 1.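

In this assay methylsulfanyl in place of nitro on an aromatic carbon, para to a group of 4 heavy atoms, gives a 1.4-fold lower number from compound 2 to compound 3 (0.13 log units; within the scatter) and so leaves the number within the scatter. This first single-place pair in the series shows that nitro is not required at this position to retain the level of compound 2. No available measurement explains this result. Still open, as far as these compounds go, is whether an amine or a carboxylic acid at this position would retain that level. From the compounds shown here alone, a longer chain in place of methylsulfanyl is equally open.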